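Urea Nitrogen Substitution in a Biphenyl Piperidine Series

The source may report more compounds than this note shows. Statements on the series, on what has been measured and on what is new or still open speak of the compounds shown alone.

Compound 1 `Cc1ccc(CN2CCC(NC(=O)NCc3ccc(-c4ccc(F)cc4)cc3)CC2)cc1` is one of two compounds tested in an in vitro functional assay on HEK293 cells for antagonist activity at melanin-concentrating hormone receptor 1 (Homo sapiens); on this read-out higher numbers stand for larger maximal responses and lower numbers for smaller maximal responses. In this assay, going by the values given here, compound 1 gives 105%, the lower of the two numbers, while compound 2 `Cc1ccc(CN2CCC(NC(=O)NCc3ccc(-c4ccccc4)cc3)CC2)cc1` gives 124%; the only measured step, a number 19 percentage points higher from compound 1 to compound 2 (beyond the scatter), comes from hydrogen in place of fluoro on an aromatic carbon. Compound 3 `Cc1ccc(CN2CCC(NC(=O)N(CC(=O)C(C)(C)O)Cc3ccc(-c4ccc(F)cc4)cc3)CC2)cc1`, not yet measured, differs from compound 1 by ((1-hydroxy-1-methylethyl)carbonyl)methyl in place of hydrogen on an amide-type nitrogen. Among the compounds with values here, no measured step touches that amide-type nitrogen; the single step between compound 1 and compound 2 concerns the aromatic carbon and so does not bear on this change. With nothing shown to guide the size or direction, the expected step of a number 5 percentage points lower from compound 1 to compound 3 (within the scatter) is none beyond the scatter. Compound 3 is therefore estimated in this assay at 100%, within a range from 75% to 125%.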

Compound 3, largest response reached (reported as Imax), in percent of the reference or control that the assay uses: 79%
Compound 3: middle estimate off by 21 percentage points, on the high side; the measured number falls inside the stated range.
By their numbers in this assay, from the lowest: compound 3; then compound 1; then compound 2.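

In this assay, ((1-hydroxy-1-methylethyl)carbonyl)methyl in place of hydrogen on the amide-type nitrogen gives a number 26 percentage points lower from compound 1 to compound 3 (beyond the scatter). This shows that the number responds to a change at this nitrogen, a place the earlier step on the aromatic carbon did not touch, and that the change at this nitrogen runs downward from compound 1. No data are available here that explain this fall.

The compounds shown leave open whether a plain methyl on the same nitrogen, or a longer chain ending in an amine or a carboxylic acid, would move the number in the same direction or by a similar amount. They also leave open whether the same substitution would give a step of similar size with hydrogen in place of fluoro, as in compound 2.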